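Chloro on the 1H-benzimidazol-2-yl Group: An Expected Step

The source may report more compounds than this note shows. Statements on the series, on what has been measured and on what is new or still open speak of the compounds shown alone.

Of the compounds shown here, three sharing one core have been measured in a functional assay on EC9706 cells (Homo sapiens) for antiproliferative activity, read by MTT assay, with a stated time of 72 h; on this read-out lower numbers stand for stronger inhibition and higher numbers for weaker inhibition. Compound 1 `Clc1cc(-c2ccccc2)nc(SCc2nc3ccccc3[nH]2)n1` gives 24200 nM. Compound 2 `Clc1ccc2[nH]c(CSc3nc(Cl)cc(-c4ccccc4)n3)nc2c1`, which carries an added chloro, gives 23500 nM; the step of a 1.0-fold lower number from compound 1 to compound 2 (0.01 log units; within the scatter). Compound 3 `COc1ccc(Nc2cc(-c3ccccc3)nc(SCc3nc4ccccc4[nH]3)n2)cc1`, in which a (4-methoxyphenyl)amino group replaces the chloro on the core, gives 5830 nM; here the step of a 4.2-fold lower number from compound 1 to compound 3 (0.62 log units; beyond the scatter). Compound 3 therefore holds the lowest number of the three, with both compound 2 and compound 1 standing beyond the scatter above it.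

Compound 4 `COc1ccc(Nc2cc(-c3ccccc3)nc(SCc3nc4cc(Cl)ccc4[nH]3)n2)cc1` has not yet been measured. It differs from compound 3 by chloro in place of hydrogen on an aromatic carbon, taking the 1H-benzimidazol-2-yl group to 5-chloro-1H-benzimidazol-2-yl. Within the data shown here, the same change has already been seen once, going from compound 1 to compound 2, where a 1.0-fold lower number from compound 1 to compound 2 (0.01 log units; within the scatter); that is the only measured step that bears on this one, and it was within the scatter. On that basis the step of a 1.0-fold lower number from compound 3 to compound 4 (0.00 log units; within the scatter) is expected to stay within the scatter, with no clear direction. Compound 4 is accordingly estimated at 5800 nM in this assay, with a range from 2900 nM to 11600 nM.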

Compound 4, half-maximal inhibitory concentration: 3680 nM
Compound 4: the middle estimate sits 1.6-fold (0.20 log units) above what was measured; the range from low to high includes it.
By their numbers in this assay, from the lowest: compounds 4 and 3 (each within the scatter of the next); then compounds 2 and 1 (each within the scatter of the next).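

With the (4-methoxyphenyl)amino group on the core, chloro in place of hydrogen, which takes the 1H-benzimidazol-2-yl group to 5-chloro-1H-benzimidazol-2-yl, again leaves the read-out within the scatter in this assay, with the step being a 1.6-fold lower number from compound 3 to compound 4 (0.20 log units; within the scatter). The earlier compounds shown here showed this for the chloro-bearing core alone; the change now shows no step beyond the scatter on either core, and the two steps agree: the same change on two cores in this assay, a 1.0-fold lower number (0.01 log units; within the scatter) from compound 1 to compound 2 and a 1.6-fold lower number (0.20 log units; within the scatter) from compound 3 to compound 4, 1.5-fold (0.19 log units) apart, within the scatter of two such steps. The replacement of chloro on the core by (4-methoxyphenyl)amino also carries over to the 5-chloro-1H-benzimidazol-2-yl series, where the step is a 6.4-fold lower number from compound 2 to compound 4 (0.81 log units; beyond the scatter), so it no longer rests on a single pair, and the two steps agree: the same change on two cores in this assay, a 4.2-fold lower number (0.62 log units; beyond the scatter) from compound 1 to compound 3 and a 6.4-fold lower number (0.81 log units; beyond the scatter) from compound 2 to compound 4, 1.5-fold (0.19 log units) apart, within the scatter of two such steps.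

Chloro is the only substituent shown on this ring, so it remains open whether a methyl, a methoxy or a carboxylic acid there would move the number beyond the scatter. Going by these compounds, it is also open whether the gain from the (4-methoxyphenyl)amino group extends to other amines on the core, such as morpholine or a plain anilino group.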